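Hydrogen for methyl on the nitrogen of compound 1

This account rests on a few compounds, and the source may have more. Where it says the series, first, only, none or still open, it means among the compounds named here.

Going by the values given here, in a functional assay on WRL68 cells (Homo sapiens) for cytotoxicity, read by MTT assay, with stated times of 6 h and 48 h (a lower number here means a stronger inhibitor, a higher number a weaker inhibitor), compound 1 `Cn1c(/C=C/C(=O)c2ccccc2O)cc(Br)c1Br` gives 330 nM as the lowest of the numbers so far. Compound 3 `Cn1c(/C=C/C(=O)c2cc(O)ccc2O)cc(Br)c1Br` gives 880 nM as the nearest number. Compound 2 `Cn1c(/C=C/C(=O)c2ccccc2)cc(Br)c1Br` stands at >= 100000 nM which is a limit and not a number.

Two measured steps start from compound 1. Hydrogen in place of hydroxy on an aromatic carbon gives an at least 300-fold higher number from compound 1 to compound 2 (2.48 log units; beyond the scatter) as a large step that ends at the limit. Hydroxy in place of hydrogen on an aromatic carbon gives a 2.7-fold higher number from compound 1 to compound 3 (0.43 log units; beyond the scatter) as a modest step.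

The next compound is compound 4 `O=C(/C=C/c1cc(Br)c(Br)[nH]1)c1ccccc1O` which has hydrogen in place of methyl on an aromatic nitrogen. The counted difference is hydrogen in place of methyl on an aromatic nitrogen and the rest of the core of compound 1 stays the same. Neither measured step touches this nitrogen, so the evidence for this change is indirect. Compound 4 keeps the hydroxy whose loss gave an at least 300-fold higher number from compound 1 to compound 2 (2.48 log units; beyond the scatter) as its step, so no fall to the limit is expected. In this assay a modest step is expected, with a higher number somewhat more likely than a lower one. The estimated step is a 1.8-fold higher number from compound 1 to compound 4 (0.26 log units; within the scatter) with wide uncertainty. For compound 4 the estimated value is 600 nM with 150 nM and 3000 nM as the expected ends of the range.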

Compound 4, half-maximal inhibitory concentration: 1420 nM
Beside the measured number, compound 4's estimate is 2.4-fold (0.37 log units) below it; the measured number falls inside the stated range.
By their numbers in this assay, from the lowest: compound 1; then compounds 3 and 4 (each within the scatter of the next). At a limit, above all of these: compound 2.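

Hydrogen in place of methyl on the aromatic nitrogen gives a 4.3-fold higher number from compound 1 to compound 4 (0.63 log units; beyond the scatter) in this assay, which is the first direct reading at this position and shows that the methyl is not neutral here. With the hydroxy of compound 1 kept, compound 4 still gives a measured number and not a limit, so the loss of the methyl leaves a modest step, while the loss of the hydroxy gives an at least 300-fold higher number from compound 1 to compound 2 (2.48 log units; beyond the scatter). The compounds shown hold no measurement that accounts for the step at the nitrogen.

Open, from the compounds shown here alone, is whether an ethyl group, a longer alkyl chain or an acetyl group on this nitrogen would keep the number of compound 1, lower it further or raise it, which would tell whether the methyl itself matters or any group in place of hydrogen would do. Also open, going by these compounds, is whether the step at the nitrogen holds with the second hydroxy of compound 3 present, and whether it can be read at all without the hydroxy, given that compound 2 stands at a limit.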